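Halogenated Aryl Replaces Catechol on the Hydrazone Carbon

A few compounds are considered here, and "the series" means these few. Any claim that something is new, unique, unknown or untested is made for them only; others in the source may bear on it.

Compound 1 `COc1ccc(/C=N/NC(=O)Nc2ccc(Oc3ccnc(-c4nncn4CCN(C)C)c3)c(F)c2)c(OC)c1` and compound 2 `CN(C)CCn1cnnc1-c1cc(Oc2ccc(NC(=O)N/N=C/c3ccc(O)c(O)c3)cc2F)ccn1` share one core and differ only in the aryl group on the carbon with a double bond to nitrogen. In a functional assay on A549 cells (Homo sapiens) for cytotoxicity, read by MTT assay, with a stated time of 72 h (a lower number here means a stronger inhibitor, a higher number a weaker inhibitor), compound 1 gives 2820 nM. In this assay compound 2 gives only a limit, > 100000 nM, so compound 2 stands at the limit of > 100000 nM in this assay, at which 1 of the 2 values shown sits. Among the compounds with values here, the single measured step, an at least 35-fold higher number from compound 1 to compound 2 (1.54 log units; beyond the scatter), is large and runs toward weaker inhibition.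

Compound 3 `CN(C)CCn1cnnc1-c1cc(Oc2ccc(NC(=O)N/N=C/c3ccc(F)cc3Cl)cc2F)ccn1` takes the next step: 2-chloro-4-fluorophenyl in place of 3,4-dihydroxyphenyl on a carbon with a double bond to nitrogen. This step removes the 3,4-dihydroxyphenyl whose arrival coincided with an at least 35-fold higher number from compound 1 to compound 2 (1.54 log units; beyond the scatter), so a return toward the level of compound 1 is expected rather than a further loss. The expected step is an at least 33-fold lower number from compound 2 to compound 3 (1.52 log units; beyond the scatter), downward and beyond the scatter. For compound 3 the estimate in this assay is 3000 nM, with a range from 800 nM to 30000 nM.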

Compound 3, half-maximal inhibitory concentration: 1120 nM
For compound 3 the middle estimate is 2.7-fold (0.43 log units) above the measured one, within the range that was stated.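

In this assay the change to 2-chloro-4-fluorophenyl on the carbon with a double bond to nitrogen gives an at least 89-fold lower number from compound 2 to compound 3 (1.95 log units; beyond the scatter), so the aryl group at this position can restore activity in the cells on an otherwise unchanged core. The value for compound 2 is a limit and not a number: the limit of > 100000 nM in this assay, at which 1 of the 3 values shown sits. The change also goes past the starting point, with a 2.5-fold lower number from compound 1 to compound 3 (0.40 log units; beyond the scatter), so among these three compounds 2-chloro-4-fluorophenyl gives the lowest number and 3,4-dihydroxyphenyl stands alone in its loss.

Going by these compounds, whether the chlorine, the fluorine or both carry the step to compound 3 stays open, as does whether the loss in compound 2 follows its two hydroxyl groups as such. A 2-chlorophenyl, 4-fluorophenyl or 3,4-dimethoxyphenyl group at this position would bear on both questions.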